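The source may hold more compounds than are shown below. What is called first, only, known or untested is meant among the compounds shown, and "the series" means these compounds.

Of the compounds shown here, three built on one shared core have so far been tested in a functional assay on PC-3 cells (Homo sapiens) for cytotoxicity, read by MTT assay, with a stated time of 72 h; on this read-out lower numbers stand for stronger inhibition and higher numbers for weaker inhibition. Compound 1 `COc1ccc(/C=C/C(=O)Nc2cc3c(Nc4ccc(F)c(Cl)c4)ncnc3cc2OC)c(OC)c1` gives 38500 nM. Compound 3 `COc1cc2ncnc(Nc3ccc(F)c(Cl)c3)c2cc1NC(=O)/C=C/c1cc(OC)c(OC)c(OC)c1` gives 38200 nM, and the step of a 1.0-fold lower number from compound 1 to compound 3 (0.00 log units; within the scatter) shows that exchanging one aryl group for another left the number where it was. Compound 2 `COc1cc(/C=C/C(=O)Nc2cc3c(Nc4ccc(F)c(Cl)c4)ncnc3cc2O[C@H]2CCOC2)cc(OC)c1OC` gives 20500 nM and so holds the lowest number of the three, though both other numbers lie within the scatter of it; the step of a 1.9-fold higher number from compound 2 to compound 3 (0.27 log units; within the scatter) is likewise small.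

Compound 4 `N#Cc1ccc(/C=C/C(=O)Nc2cc3c(Nc4ccc(F)c(Cl)c4)ncnc3cc2O[C@H]2CCOC2)cc1` has not yet been measured. It differs from compound 2 in one place: 4-cyanophenyl in place of 3,4,5-trimethoxyphenyl on a double-bonded chain carbon bound to a double-bonded chain carbon. Of the measured steps, only a 1.0-fold lower number from compound 1 to compound 3 (0.00 log units; within the scatter) concerns a swap of the aryl group on a double-bonded chain carbon bound to a double-bonded chain carbon, and it stayed within the scatter. No step beyond the scatter is therefore expected, and for compound 4 the expected step is a 1.2-fold higher number from compound 2 to compound 4 (0.09 log units; within the scatter). Compound 4 is expected to give about 25000 nM, within a range from 10000 nM to 60000 nM.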

Compound 4, half-maximal inhibitory concentration: 36600 nM
The estimate for compound 4 lay 1.5-fold (0.17 log units) below the measured number; the range from low to high includes it.
By their numbers in this assay, from the lowest: compounds 2, 4, 3 and 1 (each within the scatter of the next).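

In this assay, among these compounds, the step of a 1.8-fold higher number from compound 2 to compound 4 (0.25 log units; within the scatter) is the first test of an aryl change on a double-bonded chain carbon bound to a double-bonded chain carbon with oxolan-3-yl on the oxygen. The earlier aryl swap exchanged one methoxy-bearing ring for another, whereas here 3,4,5-trimethoxyphenyl gives way to 4-cyanophenyl, a ring with a nitrile and no methoxy groups, and the step still stays within the scatter. So, across these two swaps, the number does not respond measurably to the change of aryl group, and nothing available explains why.

Going by these compounds, it remains open whether an aryl ring carrying an amine or a carboxylic acid would move the number beyond the scatter. The same question stands for a saturated ring such as cyclohexyl in place of the aryl group.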